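This account rests on a few compounds, and the source may have more. Where it says the series, first, only, none or still open, it means among the compounds named here.

Measured so far: compound 1 `Cc1ccc(OS(=O)(=O)c2ccc(N3CCN(C)C3=O)cc2)c(C)c1` gives 2500 nM; compound 3 `CCCCN1CCN(c2ccc(S(=O)(=O)Oc3ccccc3)cc2)C1=O` gives 8800 nM; compound 2 `CN1CCN(c2ccc(S(=O)(=O)Oc3cccc([N+](=O)[O-])c3)cc2)C1=O` sits at a limit, > 100000 nM.

In a functional assay on MCF7 cells (Homo sapiens) for antiproliferative activity, read by sulforhodamine B assay, with a stated time of 48 h (a lower number here means a stronger inhibitor, a higher number a weaker inhibitor), compound 3 gives the highest of the two numbers shown, and the gap to compound 1 lies beyond the scatter. The value of compound 2 is a limit of the assay, not a number (the limit of > 100000 nM in this assay, at which 1 of the 3 values shown sits).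

Compound 4 `CCCCN1CCN(c2ccc(S(=O)(=O)Oc3ccc(OC)cc3)cc2)C1=O` is not yet measured. It differs from compound 3 by methoxy in place of hydrogen on an aromatic carbon. For the measured compounds named here, no comparable step between measured compounds is available, so the size of the change is open; a step near the scatter, in either direction, is expected. Compound 4 is estimated to give 6000 nM, between 2000 nM and 20000 nM. That estimate means a step of a 1.5-fold lower number from compound 3 to compound 4 (0.17 log units; within the scatter).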

Compound 4, half-maximal inhibitory concentration: 2500 nM
For compound 4 the middle estimate is 2.4-fold (0.38 log units) above the measured one, and the stated range covers the measured number.
By their numbers in this assay, from the lowest: compounds 1 and 4 (each within the scatter of the next); then compound 3. At a limit, above all of these: compound 2.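

In this assay, the change from phenoxy to 4-methoxyphenoxy gives a 3.5-fold lower number from compound 3 to compound 4 (0.55 log units; beyond the scatter), a modest step. For the compounds shown here, it is the first single change that can be read here, and it shows that this aromatic carbon, para to a large group, accepts methoxy with a lower number rather than a higher one. Nothing measured here gives a reason for this step. On these data alone, whether a hydroxyl, a chlorine or an amine on the same carbon would shift the number the same way remains open. So does whether methoxy would have the same effect with a methyl group in place of the butyl chain.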